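Small substituents on the exocyclic chain of a penicillanate scaffold

The source may report more compounds than this note shows. Statements on the series, on what has been measured and on what is new or still open speak of the compounds shown alone.

Measured compounds and values:
- Compound 1, `CC1(C)S[C@@H]2/C(=C\C(=O)c3ccc4ccccc4c3)C(=O)N2[C@H]1C(=O)OC(c1ccccc1)c1ccccc1`: 36500 nM
- Compound 2, `CC1(C)S[C@@H]2/C(=C\C(=O)c3ccc([N+](=O)[O-])cc3)C(=O)N2[C@H]1C(=O)OC(c1ccccc1)c1ccccc1`: 50300 nM
- Compound 3, `CCOC(=O)/C=C1/C(=O)N2[C@@H]1SC(C)(C)[C@@H]2C(=O)OC(c1ccccc1)c1ccccc1`: 7000 nM

All three share one core and differ only in the group attached to a carbonyl carbon on the exocyclic double bond. In a functional assay on A-375 cells (Homo sapiens) for cytotoxicity, read by MTT assay, with a stated time of 48 h (a higher number here means a weaker inhibitor, a lower number a stronger inhibitor), compound 3 gives the lowest number of the three, and its distance to the others is beyond the scatter: a 5.2-fold lower number from compound 1 to compound 3 (0.72 log units; beyond the scatter) and a 7.2-fold lower number from compound 2 to compound 3 (0.86 log units; beyond the scatter). Compounds 1 and 2 sit close together, as a 1.4-fold higher number from compound 1 to compound 2 (0.14 log units; within the scatter) shows.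

Compound 4, `CC(=O)/C=C1/C(=O)N2[C@@H]1SC(C)(C)[C@@H]2C(=O)OC(c1ccccc1)c1ccccc1`, is not yet measured. Its change from compound 3 is methyl in place of ethoxy on a carbonyl carbon. Within the data shown here, no measured step swaps one small group for another at this position; the two known steps both replace a ring on that carbonyl carbon with ethoxy, and both lower the number by a modest amount. Compound 4 keeps a small group there, so a step of that size is not expected; the step from compound 3 to compound 4 is estimated to be small and uncertain in direction, roughly a 1.4-fold higher number from compound 3 to compound 4 (0.15 log units; within the scatter).

For compound 4 in this assay the expected value is 10000 nM, with a range from 3500 nM to 30000 nM.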

Compound 4, half-maximal inhibitory concentration: 63000 nM
Compound 4: middle estimate off by 6.3-fold (0.80 log units), on the low side; measured number outside the range, above it.
By their numbers in this assay, from the lowest: compound 3; then compounds 1, 2 and 4 (each within the scatter of the next).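

Being small is not enough at this position. Replacing ethoxy with methyl on the carbonyl carbon, which turns ethoxycarbonyl into acetyl, gives a 9.0-fold higher number from compound 3 to compound 4 (0.95 log units; beyond the scatter) in this assay, even though neither group has a ring. The two earlier steps could have suggested that removing the ring from this carbonyl carbon was what lowered the number, but compound 4 has no ring there and still cannot be told apart from the compounds that do, with a 1.3-fold higher number from compound 2 to compound 4 (0.10 log units; within the scatter) and a 1.7-fold higher number from compound 1 to compound 4 (0.24 log units; within the scatter). Among these four compounds, then, only the ethoxy group of compound 3 stands apart, while methyl, 4-nitrophenyl and naphthalen-2-yl form one group within the scatter.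

No measurement shown here accounts for the gap between ethoxy and methyl. The compounds shown leave open whether the oxygen or the chain length of ethoxy matters more: a methoxy group would keep the oxygen with a shorter chain, an ethyl group would remove the oxygen while keeping a two-carbon chain, and an amine on the same carbonyl carbon would replace that oxygen with nitrogen.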